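The source may report more compounds than this note shows. Statements on the series, on what has been measured and on what is new or still open speak of the compounds shown alone.

Of the compounds shown here, three sharing one core have been measured in a functional assay on HeLa cells (Homo sapiens) for antiproliferative activity, read by CCK-8 assay, with a stated time of 72 h; on this read-out higher numbers stand for weaker inhibition and lower numbers for stronger inhibition. Compound 1 `O=C(Nc1cccc(-c2oc3cc(-c4ccc(F)cc4)ccc3c(=O)c2O)c1)c1ccc(F)cc1` gives 5350 nM in this assay. Compound 2 `COc1ccccc1C(=O)Nc1cccc(-c2oc3cc(-c4ccc(F)cc4)ccc3c(=O)c2O)c1`, which carries a 2-methoxyphenyl on the carbonyl carbon, gives 14100 nM. Compound 3 `O=C(Nc1cccc(-c2oc3cc(-c4ccc(F)cc4)ccc3c(=O)c2O)c1)c1ccc(C(F)(F)F)cc1` gives 17400 nM. Among these, compound 2 stands second highest: it sits a 2.6-fold higher number from compound 1 to compound 2 (0.42 log units; beyond the scatter), and the step of a 1.2-fold higher number from compound 2 to compound 3 (0.09 log units; within the scatter) is within the scatter, so compound 2 and compound 3 cannot be told apart. Compound 4 `COc1cccc(C(=O)Nc2cccc(-c3oc4cc(-c5ccc(F)cc5)ccc4c(=O)c3O)c2)c1` differs from compound 2 by 3-methoxyphenyl in place of 2-methoxyphenyl on a carbonyl carbon. Going by the values given here, no measured pair shows this same move of the methoxy group, so the closest guide is that the steps of a 2.6-fold higher number from compound 1 to compound 2 (0.42 log units; beyond the scatter) and a 3.3-fold higher number from compound 1 to compound 3 (0.51 log units; beyond the scatter) were modest when the group on the carbonyl carbon was exchanged, while a 1.2-fold higher number from compound 2 to compound 3 (0.09 log units; within the scatter) showed no real change. For compound 4 the expectation is therefore a step of a 1.2-fold lower number from compound 2 to compound 4 (0.07 log units; within the scatter) in this assay, that is, no change beyond the scatter in either direction. Compound 4 is estimated at 12000 nM, with a range from 5000 nM to 30000 nM.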

Compound 4, half-maximal inhibitory concentration: 5650 nM
For compound 4 the middle estimate is 2.1-fold (0.33 log units) above the measured one; low and high end bracket the measured number.
By their numbers in this assay, from the lowest: compounds 1 and 4 (each within the scatter of the next); then compounds 2 and 3 (each within the scatter of the next).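

Moving the methoxy group, so that 3-methoxyphenyl replaces 2-methoxyphenyl on the carbonyl carbon with no atom gained or lost, gives a 2.5-fold lower number from compound 2 to compound 4 (0.40 log units; beyond the scatter) in this assay, so at this position the arrangement of the group matters and not only its atoms. The same 3-methoxyphenyl group gives a 3.1-fold lower number from compound 3 to compound 4 (0.49 log units; beyond the scatter), whereas a 1.1-fold higher number from compound 1 to compound 4 (0.02 log units; within the scatter) stays within the scatter, so compound 1 and compound 4 cannot be told apart, although they carry different groups at this position. Nothing available here explains why the two methoxyphenyl groups differ.

It remains open where 4-methoxyphenyl would fall among these compounds, which would complete the set of methoxy isomers. As far as these compounds go, it is also open how a phenyl ring carrying an amine or a carboxylic acid would read out at this position.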